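The source may report more compounds than this note shows. Statements on the series, on what has been measured and on what is new or still open speak of the compounds shown alone.

In a functional assay on HepG2 cells (Homo sapiens) for cytotoxicity, read by MTT assay, with a stated time of 72 h (on this read-out higher numbers stand for weaker inhibition and lower numbers for stronger inhibition), compound 1 (`Cc1ccc(S(=O)(=O)OCCCc2cn(-c3ccc(C(F)(F)F)cc3)nn2)cc1`) gives 42600 nM. Compound 2 (`COC(=O)c1ccc(-n2cc(CCCOS(=O)(=O)c3ccc(C)cc3)nn2)cc1`) reads > 100000 nM, which is a limit of the assay. Compound 3 (`COc1ccc(-n2cc(CCCOS(=O)(=O)c3ccc(C)cc3)nn2)cc1`) reads > 100000 nM, also a limit and not a number, so it stands at the limit of > 100000 nM in this assay, at which 2 of the 3 values shown sit.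

Compound 4 (`Cc1ccc(S(=O)(=O)OCCCc2cn(-c3cccc(F)c3)nn2)cc1`) has 3-fluorophenyl in place of 4-methoxyphenyl on an aromatic nitrogen. Within the data shown here, two measured steps bear on this change, both beyond the scatter. Methoxy in place of trifluoromethyl gave an at least 2.3-fold higher number from compound 1 to compound 3 (0.37 log units; beyond the scatter), and methoxycarbonyl in place of trifluoromethyl gave an at least 2.3-fold higher number from compound 1 to compound 2 (0.37 log units; beyond the scatter). The third step, a step that the two limits leave unreadable from compound 2 to compound 3, adds nothing.

Among the measured compounds shown here, only compound 1, at 42600 nM, has a measurable value, and it is the one compound so far with fluorine on its aryl group. A modest move towards stronger inhibition is therefore expected, though the result may again be only a limit. The expected step is an at least 1.5-fold lower number from compound 3 to compound 4 (0.18 log units; that floor lies within the scatter). For compound 4 the estimate is 65000 nM, with an expected range from 30000 nM to 100000 nM.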

Compound 4, half-maximal inhibitory concentration: 61800 nM
For compound 4 the middle estimate is 1.1-fold (0.02 log units) above the measured one; the range from low to high includes it.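

On the aromatic nitrogen, 3-fluorophenyl in place of 4-methoxyphenyl brings an at least 1.6-fold lower number from compound 3 to compound 4 (0.20 log units; that floor lies within the scatter) in this assay. Going by these compounds, compound 3 holds a limit and not a number, so only this floor can be read for the change, and the true size of the step stays unknown. Compound 4 is the second compound, after compound 1, to give a number rather than a limit, which shows that a measurable value at this position does not require trifluoromethyl.

On these data alone, how 4-fluorophenyl, or an aryl group carrying an amine or a carboxylic acid, would read in this assay stays open. Readable comparisons also remain few, and part of the series still gives no number: the limit of > 100000 nM in this assay, at which 2 of the 4 values shown sit.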